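Solubility of Three Measured Compounds and One Still to Come

A few compounds are considered here, and "the series" means these few. Any claim that something is new, unique, unknown or untested is made for them only; others in the source may bear on it.

Compound 1 `Cc1ccccc1-c1nc(CN2CCC(C(=O)NCCN3C[C@H](C)C[C@H](C)C3)CC2)c(C)o1`: > 67 ug/mL
Compound 2 `Cc1cccc(Cl)c1-c1nc(CN2CCC(C(=O)NCCCN3CCC(C(C)C)CC3)CC2)c(C)o1`: > 76 ug/mL
Compound 3 `Cc1oc(-c2c(Cl)cccc2C(F)(F)F)nc1CN1CCC(C(=O)NCCCN2C[C@H](C)C[C@H](C)C2)CC1`: 65.1 ug/mL

In a physicochemical assay for solubility, in phosphate buffer, measured as kinetic solubility, at pH 7.4 (on this read-out higher numbers stand for higher solubility and lower numbers for lower solubility), compound 1 reaches only a limit of the assay, (the limit of > 67 ug/mL in this assay, at which 1 of the 3 values shown sits). Compound 2 also sits at a limit, (the limit of > 76 ug/mL in this assay, at which 1 of the 3 values shown sits). Among the compounds with values here, compound 3 is the one compound of the three with an actual number in this assay, 65.1 ug/mL.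

Compound 4 `COc1ccc(-c2nc(CN3CCC(C(=O)NCCCN4C[C@H](C)C[C@H](C)C4)CC3)c(C)o2)cc1OC` has not been measured. It differs from compound 3 in one place: 3,4-dimethoxyphenyl in place of 2-chloro-6-(trifluoromethyl)phenyl on an aromatic carbon. Within the data shown here, no measured pair differs in one place, so no step gives a precedent for the size of this change. The step is expected to be a moderate rise in this assay, a 1.4-fold higher number from compound 3 to compound 4 (0.14 log units; within the scatter). Compound 4 is estimated at 90 ug/mL, with a range from 45 ug/mL to 180 ug/mL.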

Compound 4, solubility: > 76 ug/mL
Compound 4 ended at the assay's limit (the forecaster's own chance of this, stated with the estimate: 60%); the middle value lies beyond the limit too.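

In this assay, within the data shown here, the change to 3,4-dimethoxyphenyl in place of 2-chloro-6-(trifluoromethyl)phenyl gives an at least 1.1-fold higher number from compound 3 to compound 4 (0.06 log units; that floor lies within the scatter) on this aromatic carbon, the first step here between compounds that differ in one place. The value of compound 4 is a limit of the assay and not a number. This step is therefore only a floor, so it shows no fall on swapping these two groups, while its true size cannot be read. Going by these compounds, whether an amine or a carboxylic acid on this phenyl ring would give a similar read-out stays open.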